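Removing one hydroxy from compound 3

The source may report more compounds than this note shows. Statements on the series, on what has been measured and on what is new or still open speak of the compounds shown alone.

Measured in a functional assay (Mus musculus) for inhibition, with a stated time of 5 days; a lower number here means a stronger inhibitor, a higher number a weaker inhibitor:
- Compound 1 `CCOC(=O)/C=C/c1cn(-c2ccc(O)cc2)nc1-c1cccc(O)c1`: 14000 nM
- Compound 2 `O=C(O)/C=C/c1cn(-c2ccc(O)cc2)nc1-c1ccc(O)cc1`: > 100000 nM (a limit)
- Compound 3 `CCOC(=O)/C=C/c1cn(-c2ccc(O)cc2)nc1-c1ccc(O)c(O)c1`: 6200 nM

Only two of these results are actual numbers, and compound 3 holds the lower one at 6200 nM, with compound 1 the nearest at 14000 nM. For the measured compounds named here, compound 2 reports only a limit, > 100000 nM, and gives no step.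

Compound 4 `CCOC(=O)/C=C/c1cn(-c2ccc(O)cc2)nc1-c1ccc(O)cc1` follows from compound 3 by hydrogen in place of hydroxy on an aromatic carbon, which turns 3,4-dihydroxyphenyl into 4-hydroxyphenyl. Going by the values given here, one measured step bears on this, a 2.3-fold lower number from compound 1 to compound 3 (0.35 log units; beyond the scatter). That modest step also exchanges hydrogen and hydroxy on an aromatic carbon, but in the opposite sense, and the hydroxy that leaves here is not the one that entered there. The guide is therefore loose, and a modest move to a higher number is expected in this assay. The expected change is a 2.1-fold higher number from compound 3 to compound 4 (0.32 log units; beyond the scatter). For compound 4 the estimate is 13000 nM, with an expected range of 5000 nM to 40000 nM.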

Compound 4, half-maximal inhibitory concentration: 25000 nM
The estimate for compound 4 lay 1.9-fold (0.28 log units) below the measured number; the range from low to high includes it.
By their numbers in this assay, from the lowest: compound 3; then compounds 1 and 4 (each within the scatter of the next). At a limit, above all of these: compound 2.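

In this assay, removing the hydroxy that sits ortho to a hydroxy group gives a 4.0-fold higher number from compound 3 to compound 4 (0.61 log units; beyond the scatter), so the 3,4-dihydroxyphenyl group holds an advantage over 4-hydroxyphenyl as well as over the 3-hydroxyphenyl of compound 1. Between the two single-hydroxy compounds the assay draws no distinction (a 1.8-fold higher number from compound 1 to compound 4 (0.25 log units; within the scatter)), so in these compounds the lower number goes with having both hydroxy groups rather than with which one remains. The ethyl on the oxygen next to the carbonyl group also matters (an at least 4.0-fold lower number from compound 2 to compound 4 (0.60 log units; beyond the scatter)), though this step is only a bound, with compound 2 reporting a limit: (the limit of > 100000 nM in this assay, at which 1 of the 4 values shown sits).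

The compounds shown leave open whether a methoxy or an amine at this place would match or improve on the hydroxy of compound 3. They also leave open how a longer chain or an amide would compare with the ethyl ester.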